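This account rests on a few compounds, and the source may have more. Where it says the series, first, only, none or still open, it means among the compounds named here.

Measured in a functional assay on PC-3 cells (Homo sapiens) for antiproliferative activity, read by MTT assay, with a stated time of 48 h; a higher number here means a weaker inhibitor, a lower number a stronger inhibitor:
- Compound 1 `COc1cc(N(Cc2ccc(C)cc2)C(=O)CSc2nc3ccccc3s2)cc(OC)c1OC`: > 80000 nM (a limit of the assay, not a number)
- Compound 2 `COc1ccc(CN(C(=O)CSc2nc3ccccc3s2)c2cc(OC)c(OC)c(OC)c2)cc1N=[N+]=[N-]`: 14400 nM
- Compound 3 `COc1ccc2nc(SCC(=O)N(Cc3ccc(OC)c(O)c3)c3cc(OC)c(OC)c(OC)c3)sc2c1`: 4110 nM

Compound 2, at 14400 nM, has the higher of the two exact numbers, which makes it the weaker of that pair. Compound 3 lies lower at 4110 nM, a gap beyond the usual scatter.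

Compound 4 `COc1ccc(CN(C(=O)CSc2nc3ccccc3s2)c2cc(OC)c(OC)c(OC)c2)cc1OC` is not yet measured. It has methoxy in place of azido on an aromatic carbon, so 3-azido-4-methoxyphenyl becomes 3,4-dimethoxyphenyl.

Within the data shown here, only one measured step bears on this change: an at least 5.5-fold lower number from compound 1 to compound 2 (0.74 log units; beyond the scatter). That step swapped 4-methylphenyl for the whole 3-azido-4-methoxyphenyl group, so it does not show what the azido alone contributes. From the compounds shown here alone, the direction of the new step therefore stays open. The expected change is a 1.1-fold lower number from compound 2 to compound 4 (0.04 log units; within the scatter), and no step beyond the scatter is expected in this assay, although the uncertainty is wide. For compound 4 the estimated value is 13000 nM, with an expected range from 3500 nM to 50000 nM.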

Compound 4, half-maximal inhibitory concentration: > 80000 nM
Compound 4 gave a limit, no number; the forecaster's own chance of this, stated with the estimate: 12%; middle value at least 6.1-fold (0.78 log units) away from the limit.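

Changing only azido to methoxy on this aromatic carbon gives, in this assay, an at least 5.5-fold higher number from compound 2 to compound 4 (0.74 log units; beyond the scatter). Compound 4 gives > 80000 nM, which is a limit of the assay and not a number. The earlier step, an at least 5.5-fold lower number from compound 1 to compound 2 (0.74 log units; beyond the scatter), replaced a whole group and could not separate the azido from the rest of it, whereas this pair differs in that one place alone and shows that, with the remainder of the 3-azido-4-methoxyphenyl group kept, replacing azido with methoxy is enough to lose the measurable number.

The step from compound 1 to compound 4 cannot be read, because both values are limits: the limit of > 80000 nM in this assay, at which 2 of the 4 values shown sit. From the compounds shown here alone, it remains open whether azido is unusual at this place, or whether another group there, such as an amine, a nitrile or a chlorine atom, would also give a measurable number.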